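Three Analogues at the Limit, and a Fourth to Come

The source may report more compounds than this note shows. Statements on the series, on what has been measured and on what is new or still open speak of the compounds shown alone.

Three compounds were tested in a functional assay on NCI-H460 cells (Homo sapiens) for cytotoxicity, read by MTT assay; on this read-out lower numbers stand for stronger inhibition and higher numbers for weaker inhibition. Compound 1, `Cc1ccc(Nc2nc(C)c(C(=O)/C=C/c3ccc(Cl)cc3)s2)cc1`, gives > 25000 nM, which is a limit of the assay and not a number. Compound 2, `Cc1nc(Nc2cccc(Cl)c2)sc1C(=O)/C=C/c1ccc(Cl)cc1`, gives > 25000 nM, again a limit of the assay and not a number. Compound 3, `COc1cccc(/C=C/C(=O)c2sc(Nc3cccc(Cl)c3)nc2C)c1`, gives > 25000 nM, once more a limit of the assay and not a number.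

Compound 2 and compound 1 differ in one place: 4-methylphenyl in place of 3-chlorophenyl on a nitrogen on an aromatic ring. All that is known of either is a limit. The step measured here is a step that the two limits leave unreadable from compound 2 to compound 1. Compound 2 and compound 3 differ in their cores: 3-methoxyphenyl in place of 4-chlorophenyl on a double-bonded chain carbon bound to a double-bonded chain carbon. That step is likewise a step that the two limits leave unreadable from compound 2 to compound 3.

Compound 4, `COc1cccc(/C=C/C(=O)c2sc(Nc3ccc(C)cc3)nc2C)c1`, has not yet been measured. It differs from compound 3 in the following way: 4-methylphenyl in place of 3-chlorophenyl on a nitrogen on an aromatic ring. Within the data shown here, this is the same change as the one from compound 2 to compound 1, made on the core of compound 3 instead. Among the measured compounds shown here, the only evidence on the measured steps is the limit of > 25000 nM in this assay, at which 3 of the 3 values shown sit, and the two readable steps give no direction of any size.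

The expected step is therefore a step that the limit leaves unreadable from compound 3 to compound 4, set beside the measured step that the two limits leave unreadable from compound 2 to compound 1, and it rests on (the limit of > 25000 nM in this assay, at which 3 of the 3 values shown sit). Compound 4 is estimated at 40000 nM, with a plausible range from 15000 nM to 150000 nM, and the expectation is that this assay will most likely again report only a limit for it.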

Compound 4, half-maximal inhibitory concentration: > 25000 nM
Compound 4: a limit, no number; the forecaster's own chance of this, stated with the estimate: 85%; the middle value does not contradict the limit.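

In this assay compound 4 gives > 25000 nM, a limit of the assay and not a number. Neither the step from compound 3 to compound 4 nor the step from compound 1 to compound 4 can be read, and no size can be given for either: the limit of > 25000 nM in this assay, at which 4 of the 4 values shown sit.

The compounds shown leave open whether either change, at the nitrogen or on the chain, alters cytotoxicity at all.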